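The compounds below may be only part of what the source reports. "The series", "measured", "known", "first", "only" and "open" are said of these compounds alone.

Measured compounds:
Compound 1, `CC1=C(C(=O)OCC(C)C)C(c2ccoc2)NC(=O)N1C`, gives 4%.
Compound 2, `COC(=O)C1=C(C)N(C)C(=O)NC1c1cccs1`, gives 30%.
Compound 3, `CCOC(=O)C1=C(C)N(C)C(=O)NC1c1cccs1`, gives 1%.

These three values come from an assay on membranes from CHO cells for displacement of a labelled ligand from adenosine receptor A1 (Homo sapiens), read by scintillation counting, with a stated time of 60 min, tested at 1 uM; a higher number here means more inhibition at the concentration tested (going by the name of the read-out), a lower number less inhibition. Among them compound 3 stands lowest, with compound 1 within the scatter of it and compound 2 well apart, a number a number 29 percentage points lower from compound 2 to compound 3 (beyond the scatter). Going by the values given here, that one step, methyl in place of hydrogen on a saturated chain carbon bound to an oxygen next to a carbonyl group, is the only measured step, and it is modest in size, running downward.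

Compound 4, `CC1=C(C(=O)OCC(C)C)C(c2cccs2)NC(=O)N1C`, differs from compound 3 in the same region: isopropyl in place of methyl on a saturated chain carbon bound to an oxygen next to a carbonyl group. Among the compounds with values here, no measured step covers exactly this change. Within the data shown here, the only guidance is that compound 1 already carries the isobutoxycarbonyl group and gives a low reading in this assay, and that compound 3 itself sits at the bottom of the three numbers, leaving little room for a further fall. The step from compound 3 to compound 4 is therefore expected to stay within the scatter, with no clear direction, estimated as a number 2 percentage points higher from compound 3 to compound 4 (within the scatter). Compound 4 is expected to give about 3% in this assay, within a range of -10% to 15%.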

Compound 4, a percentage reported as inhibition, at one concentration (the size of the read-out at that concentration, not a potency): 9%
For compound 4 the middle estimate is 6 percentage points below the measured one, within the range that was stated.
By their numbers in this assay, from the lowest: compounds 3, 1 and 4 (each within the scatter of the next); then compound 2.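

In this assay, isopropyl in place of methyl on a saturated chain carbon bound to an oxygen next to a carbonyl group gives a number 8 percentage points higher from compound 3 to compound 4 (within the scatter) and so leaves the reading unresolved from that of the ethoxycarbonyl compound, which shows that going from ethoxycarbonyl to isobutoxycarbonyl on the thiophen-2-yl series makes no clear difference. The separation from the smallest ester seen earlier also survives this larger chain, since isopropyl in place of hydrogen at the same place gives a number 21 percentage points lower from compound 2 to compound 4 (beyond the scatter) and compound 4 stays well apart from compound 2 as compound 3 does. With the isobutoxycarbonyl group kept, thiophen-2-yl in place of furan-3-yl on a saturated ring carbon gives a number 5 percentage points higher from compound 1 to compound 4 (within the scatter) and this exchange cannot be told from the scatter.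

The compounds shown leave open whether an amine, a carboxylic acid or a chain longer than isobutyl at this place would bring the reading back towards that of compound 2. They also leave open whether furan-3-yl and thiophen-2-yl would stay equally close when carried with the smaller methoxycarbonyl group. Nothing on hand explains why the readings sit where they do.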